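Opening the Ring: From Compound 3 to Compound 4

This account rests on a few compounds, and the source may have more. Where it says the series, first, only, none or still open, it means among the compounds named here.

Compound 1 `CCCCCCCCCCc1ccc(-c2noc(CC3CNC3)n2)cc1`: 63%
Compound 2 `CCCCCCCCCCc1ccc(-c2noc(CN3CCNCC3)n2)cc1`: 19%
Compound 3 `CCCCCCCCCCc1ccc(-c2noc([C@@H]3CCC[C@@H](N)C3)n2)cc1`: 13%

In an assay on HeLa cells for inhibition of sphingosine-1-phosphate transporter SPNS2 (Mus musculus), read by LC-MS, tested at 2 uM (a higher number here means more inhibition at the concentration tested (going by the name of the read-out), a lower number less inhibition), compound 3 stands lowest of the three numbers; the steps leading to it are a number 6 percentage points lower from compound 2 to compound 3 (within the scatter) and a number 50 percentage points lower from compound 1 to compound 3 (beyond the scatter). Compound 4 `CCCCCCCCCCc1ccc(-c2noc(CC(O)CN)n2)cc1` is the next change: 3-amino-2-hydroxypropyl in place of 3-aminocyclohexyl on an aromatic carbon. Among the measured compounds shown here, only two measured steps bear on this kind of change, both altering the amine-bearing group at the same place on the shared core: a number 44 percentage points lower from compound 1 to compound 2 (beyond the scatter) was large, while a number 6 percentage points lower from compound 2 to compound 3 (within the scatter) stayed within the scatter. So swapping one amine-bearing group for another can move the number far or hardly at all. Compound 4 is expected to land near 25%, between 5% and 55%, a step estimated as a number 12 percentage points higher from compound 3 to compound 4 (beyond the scatter).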

Compound 4, a percentage reported as inhibition, at one concentration (the size of the read-out at that concentration, not a potency): 59%
For compound 4 the middle estimate is 34 percentage points below the measured one; the whole stated range lies below it.
By their numbers in this assay, from the lowest: compounds 3 and 2 (each within the scatter of the next); then compounds 4 and 1 (each within the scatter of the next).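

In this assay, an open chain does what the ring did not: 3-amino-2-hydroxypropyl in place of 3-aminocyclohexyl gives a number 46 percentage points higher from compound 3 to compound 4 (beyond the scatter). The same group, set against the piperazin-1-yl of compound 2, gives a number 40 percentage points higher from compound 2 to compound 4 (beyond the scatter), while against the azetidin-3-yl of compound 1 it gives a number 4 percentage points lower from compound 1 to compound 4 (within the scatter), so a ring in this group is not required for a number at the level of compound 1. Nothing measured here explains these differences.

The compounds shown leave open whether the hydroxyl or the opening of the ring accounts for the step from compound 3. A plain 3-aminopropyl chain, with the amine but no hydroxyl, would separate the two.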